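Carrying a Dimethylphenyl Swap onto a Second Core

The source may hold more compounds than are shown below. What is called first, only, known or untested is meant among the compounds shown, and "the series" means these compounds.

Compound 1 `Fc1ccc(C2=NN(C3=NC(c4ccccc4)CS3)C(c3ccc4ccccc4c3)C2)cc1`: 9730 nM in a functional assay on HeLa cells (Homo sapiens) for inhibition, read by CCK-8 assay, with a stated time of 48 h; on this read-out lower numbers stand for stronger inhibition and higher numbers for weaker inhibition
Compound 2 `Cc1ccc(C2=NN(C3=NC(c4ccccc4)CS3)C(c3ccc4ccccc4c3)C2)cc1C`: 950 nM
Compound 3 `O=C1CSC(N2N=C(c3ccc(F)cc3)CC2c2ccc3ccccc3c2)=N1`: 9170 nM

Compound 2 differs from compound 1 by 3,4-dimethylphenyl in place of 4-fluorophenyl on a carbon with a double bond to nitrogen and that step was a 10-fold lower number from compound 1 to compound 2 (1.01 log units; beyond the scatter). Compound 3 has a different core: the difference from compound 1 is a group of 6 heavy atoms (3 carbon, 1 nitrogen, 1 oxygen, 1 sulfur; one five-membered non-aromatic ring with 2 hetero atoms) in place of a group of 11 heavy atoms (9 carbon, 1 nitrogen, 1 sulfur; one five-membered non-aromatic ring with 2 hetero atoms, one six-membered aromatic ring of carbon only), on an amine nitrogen in a ring and the step was a 1.1-fold lower number from compound 1 to compound 3 (0.03 log units; within the scatter). Compound 4 `Cc1ccc(C2=NN(C3=NC(=O)CS3)C(c3ccc4ccccc4c3)C2)cc1C` repeats the swap on the core of compound 3: 3,4-dimethylphenyl in place of 4-fluorophenyl on a carbon with a double bond to nitrogen. The surroundings are not identical, since here the carbon is two ring bonds from the ring atom that bears a group of 6 heavy atoms, whereas in compound 1 it is two ring bonds from the ring atom that bears a naphthalen-2-yl group, so this is the same kind of change rather than the same change. Because the earlier swap gave a 10-fold lower number from compound 1 to compound 2 (1.01 log units; beyond the scatter), compound 4 is expected to gain about as much, a 9.2-fold lower number from compound 3 to compound 4 (0.96 log units; beyond the scatter). In this assay compound 4 is estimated at 1000 nM, between 300 nM and 3500 nM.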

Compound 4, half-maximal inhibitory concentration: 860 nM
For compound 4 the middle estimate is 1.2-fold (0.07 log units) above the measured one; the range from low to high includes it.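

On the core of compound 3, 3,4-dimethylphenyl in place of 4-fluorophenyl gave an 11-fold lower number from compound 3 to compound 4 (1.03 log units; beyond the scatter) in this assay, so the swap carried over to the second core at much the same size: the same change on two cores in this assay, a 10-fold lower number (1.01 log units; beyond the scatter) from compound 1 to compound 2 and an 11-fold lower number (1.03 log units; beyond the scatter) from compound 3 to compound 4, 1.0-fold (0.02 log units) apart, within the scatter of two such steps

The exchange of cores, read on the 3,4-dimethylphenyl compounds, gave a 1.1-fold lower number from compound 2 to compound 4 (0.04 log units; within the scatter), so the two cores could not be told apart with either aryl group: the same change on two cores in this assay, a 1.1-fold lower number (0.03 log units; within the scatter) from compound 1 to compound 3 and a 1.1-fold lower number (0.04 log units; within the scatter) from compound 2 to compound 4, 1.0-fold (0.02 log units) apart, within the scatter of two such steps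

This is one swap on two cores in one cell line, so it does not show that the step would hold on other cores, nor why it is so large.

As far as these compounds go, whether a phenyl carrying an amine or a carboxylic acid in this place would give a similar step stays open. So does the contribution of the naphthalen-2-yl group, which all four compounds share.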